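The compounds below may be only part of what the source reports. "The series", "measured", "known", "first", "only" and "open" are said of these compounds alone.

Compound 1 `Cc1cc(C(=O)O)nn1C(C)c1cc(Cl)ccc1OCc1ccccc1` gives 10 nM in an assay on CHO-K1 cells for displacement of a labelled ligand from prostaglandin E2 receptor EP1 subtype (Homo sapiens); on this read-out lower numbers stand for stronger inhibition and higher numbers for weaker inhibition.
Compound 2 `Cc1cc(C(=O)NC(C)C)nn1Cc1cc(Cl)ccc1OCc1ccccc1` gives 126 nM in this assay.
Compound 3 `Cc1cc(C(=O)Nc2ccccc2)nn1Cc1cc(Cl)ccc1OCc1ccccc1` gives 39.8 nM in this assay.

Compound 3 stands second among the three numbers measured in this assay: compound 2 lies nearest with a weaker number, compound 1 furthest with a stronger one. The next compound, compound 4 `Cc1cc(C(=O)NCc2ccccn2)nn1Cc1cc(Cl)ccc1OCc1ccccc1`, differs from compound 3 in one place: (pyridin-2-yl)methyl in place of phenyl on an amide-type nitrogen. Going by the values given here, only one measured step bears on this position, the replacement at the amide nitrogen from compound 2 to compound 3, which gave a 3.2-fold lower number from compound 2 to compound 3 (0.50 log units; beyond the scatter). Compound 4 carries a (pyridin-2-yl)methyl group on that nitrogen, which is neither the isopropyl of compound 2 nor the phenyl of compound 3, so the data give no direct guide. A step that is expected for compound 4 is a 1.6-fold higher number from compound 3 to compound 4 (0.20 log units; within the scatter), a modest weakening that would place it between the two measured amides. Compound 4 is therefore estimated at 63 nM in this assay, with a range from 20 nM to 200 nM.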

Compound 4, half-maximal inhibitory concentration: 25.1 nM
Beside the measured number, compound 4's estimate is 2.5-fold (0.40 log units) above it; the measured number falls inside the stated range.
By their numbers in this assay, from the lowest: compound 1; then compounds 4 and 3 (each within the scatter of the next); then compound 2.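

With a 1.6-fold lower number from compound 3 to compound 4 (0.20 log units; within the scatter), (pyridin-2-yl)methyl and phenyl on the amide-type nitrogen cannot be told apart in this assay, although the entering group brings a hydrogen-bond acceptor that phenyl lacks. Against isopropyl, the same group gives a 5.0-fold lower number from compound 2 to compound 4 (0.70 log units; beyond the scatter), so among these three amides both groups carrying an aromatic ring give lower numbers than isopropyl, whether that ring is attached directly to the nitrogen or through a methyl link. Nothing shown gives a reason for these numbers.

The compounds shown leave open whether the ring nitrogen or the methyl link matters at this position, and a benzyl group on the amide nitrogen would separate the two. Also open, on these data alone, is how a longer chain, such as 2-phenylethyl, or the unsubstituted amide would read here.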